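Chloro to iodo on the phenyl ring of compound 2

A few compounds are considered here, and "the series" means these few. Any claim that something is new, unique, unknown or untested is made for them only; others in the source may bear on it.

Measured so far:
compound 1 `CCSc1ncnc2c1ncn2[C@@H]1O[C@H](CO)[C@@H](O)[C@H]1O`: 57500 nM
compound 2 `OC[C@H]1O[C@@H](n2cnc3c(CSc4ccccc4Cl)ncnc32)[C@H](O)[C@@H]1O`: 1780 nM

In an assay on isolated protein for binding affinity to Equilibrative nucleoside transporter 1 (Homo sapiens) (a higher number here means a weaker inhibitor, a lower number a stronger inhibitor), compound 2 gives 1780 nM and stands at the lowest of the two numbers; compound 1 gives 57500 nM. Among the compounds with values here, the one step measured, a 32-fold lower number from compound 1 to compound 2 (1.51 log units; beyond the scatter), is large and concerns the whole substituent on the core, not a halogen.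

Compound 3 `OC[C@H]1O[C@@H](n2cnc3c(CSc4ccccc4I)ncnc32)[C@H](O)[C@@H]1O` differs from compound 2 by iodo in place of chloro on an aromatic carbon, sitting on an aromatic carbon of a six-membered aromatic ring of carbon only, ortho to a large group. Within the data shown here, no measured step touches a halogen swap, so nothing sets the size of this change; the expectation is that it stays within the scatter, a step of a 1.2-fold lower number from compound 2 to compound 3 (0.07 log units; within the scatter). Compound 3 is therefore estimated at 1500 nM in this assay, with a range from 500 nM to 4500 nM.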

Compound 3, half-maximal inhibitory concentration: 282 nM
For compound 3 the middle estimate is 5.3-fold (0.73 log units) above the measured one; the whole stated range lies above it.
By their numbers in this assay, from the lowest: compound 3; then compound 2; then compound 1.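

In this assay the halogen on the phenyl ring is not a neutral position: iodo in place of chloro, on an aromatic carbon ortho to a large group, gives a 6.3-fold lower number from compound 2 to compound 3 (0.80 log units; beyond the scatter) with no other change to the structure. The earlier step exchanged a whole substituent, whereas this one shows that a swap of one heavy atom within that substituent, with no change in the counted donors or acceptors, moves the number beyond the scatter. The full exchange of ethylsulfanyl now stands at a 200-fold lower number from compound 1 to compound 3 (2.31 log units; beyond the scatter) and remains large; no measurement at hand explains the difference between chloro and iodo at this position.

The compounds shown leave open where bromo would fall relative to chloro and iodo on this carbon. From the compounds shown here alone, whether a non-halogen group such as methyl or methoxy could stand in for iodo there also remains open.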